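The source may report more compounds than this note shows. Statements on the series, on what has been measured and on what is new or still open speak of the compounds shown alone.

Three compounds sharing a core were examined in an ADME assay on J774.A1 cells (Mus musculus) for cytotoxicity, read by MTT assay, with a stated time of 72 h; on this read-out lower numbers stand for an effect already at smaller amounts and higher numbers for an effect only at larger amounts of compound. Compound 1 `Cc1ccc2nc(NC(C)C)nc(NCc3ccco3)c2c1` reports only a limit in this assay, namely > 33000 nM, which is a bound of the assay and not a number (the limit of > 33000 nM in this assay, at which 1 of the 3 values shown sits). Compound 2 `Cc1cccc2nc(NC(C)C)nc(NCc3ccco3)c12` gives 20000 nM in this assay, and compound 3 `COc1ccc2nc(NC(C)C)nc(NCc3ccco3)c2c1` gives 14000 nM. The difference between the cores of compound 1 and compound 2 is not broken down here. Compound 3 carries methoxy in place of methyl on an aromatic carbon relative to compound 1, and this change brings an at least 2.3-fold lower number from compound 1 to compound 3 (0.37 log units; beyond the scatter). The values of compound 2 and compound 3 lie within the scatter of each other.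

Compound 4 `COc1cccc2nc(NC(C)C)nc(NCc3ccco3)c12`, not yet measured, carries the same kind of change relative to compound 2: methoxy in place of methyl on an aromatic carbon. Here the place is ortho to a fused ring and meta to a fused ring, whereas for compound 3 it is meta to a fused ring and para to a fused ring. A lowering of the number is expected from compound 2 to compound 4, estimated as a 2.0-fold lower number from compound 2 to compound 4 (0.30 log units; within the scatter). This expectation rests on the step of an at least 2.3-fold lower number from compound 1 to compound 3 (0.37 log units; beyond the scatter). For compound 4 the expected value in this assay is 10000 nM, with a likely range from 5000 nM to 25000 nM.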

Compound 4, half-maximal effective concentration: 18000 nM
For compound 4 the middle estimate is 1.8-fold (0.26 log units) below the measured one, within the range that was stated.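

In this assay, methoxy in place of methyl on the core of compound 2 gives a 1.1-fold lower number from compound 2 to compound 4 (0.05 log units; within the scatter), so on this core the change brings no step beyond the scatter. The earlier step on the other core starts from compound 1, whose > 33000 nM is a limit of the assay and not a number: the limit of > 33000 nM in this assay, at which 1 of the 4 values shown sits. The two pairs therefore show neither that the change carries over from one core to the other at the same size nor that its size depends on the core: the same change on two cores in this assay, an at least 2.3-fold lower number (0.37 log units; beyond the scatter) from compound 1 to compound 3 and a 1.1-fold lower number (0.05 log units; within the scatter) from compound 2 to compound 4; the limit leaves it open whether they differ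

The compounds shown leave open what other groups on the same aromatic carbon would do in this assay, for example an ethoxy group, an amine or a carboxylic acid, as all four compounds carry only methyl or methoxy there. They also leave open whether the picture would hold with a longer chain on either of the two nitrogen substituents of the shared core, which stay the same throughout.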